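Benzylamine esters against a serine protease: chain tail change

The compounds below may be only part of what the source reports. "The series", "measured", "known", "first", "only" and "open" are said of these compounds alone.

Measured compounds:
- compound 1, `NCc1ccc(C(=O)OCc2ccc(Cl)cc2)cc1`, 30000000 nM
- compound 2, `NCc1ccc(C(=O)OCCCc2ccccc2)cc1`, 500000000 nM
- compound 3, `NCc1ccc(C(=O)OCc2ccccc2)cc1`, 30000000 nM

All three share a core carrying an aminomethyl group and an ester, and differ only in the group attached to the ester oxygen. In an assay on isolated protein for inhibition of serine protease 1 (Homo sapiens) (a lower number here means a stronger inhibitor, a higher number a weaker inhibitor), compound 2 gives the highest number of the three, which means it is the weakest inhibitor shown, with both compound 1 and compound 3 sitting well beyond the scatter from it. Among the compounds with values here, the only single-point step among the measured compounds is no change at the digits printed from compound 1 to compound 3 (within the scatter), which concerns a substituent on the aromatic ring of the ester side and tells nothing about the chain itself.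

Compound 4, `CCCCOC(=O)c1ccc(CN)cc1`, arises from compound 2 by the change (methyl in place of phenyl on a saturated chain carbon, three bonds along the chain from an oxygen next to a carbonyl group). Within the data shown here, no measured step bears on this kind of change, so the direction cannot be read from the data. The estimate for compound 4 in this assay is therefore anchored on compound 2, expected near 300000000 nM with a wide range from 50000000 nM to 2000000000 nM, a step of a 1.7-fold lower number from compound 2 to compound 4 (0.22 log units; within the scatter) that is expected to stay within the scatter.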

Compound 4, inhibition constant: 910000000 nM
For compound 4 the middle estimate is 3.0-fold (0.48 log units) below the measured one; the measured number falls inside the stated range.
By their numbers in this assay, from the lowest: compounds 1 and 3 (each within the scatter of the next); then compounds 2 and 4 (each within the scatter of the next).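

In this assay, methyl in place of phenyl on a saturated chain carbon, three bonds along the chain from an oxygen next to a carbonyl group, gives a 1.8-fold higher number from compound 2 to compound 4 (0.26 log units; within the scatter), so at this place the phenyl ring can be lost without a change beyond the scatter. The large shift appears with a different change: propyl in place of phenyl on a saturated chain carbon bound to an oxygen next to a carbonyl group gives a 30-fold higher number from compound 3 to compound 4 (1.48 log units; beyond the scatter), so what the phenyl ring contributes depends on where it sits. No measurement here explains either result.

The compounds shown leave open how a longer chain than that of compound 4 would read in this assay. They also leave open what an amine or a carboxylic acid at the end of that chain would do.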